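Swapping an allyloxy for methylsulfanyl on a shared core

A few compounds are considered here, and "the series" means these few. Any claim that something is new, unique, unknown or untested is made for them only; others in the source may bear on it.

Measured compounds:
- Compound 1, `c1nc(OCC2CCCCC2)c2nc[nH]c2n1`: 32300 nM
- Compound 2, `C=CCOc1ncnc2[nH]cnc12`: 44700 nM
- Compound 3, `c1ccc(Sc2ncnc3[nH]cnc23)cc1`: 31000 nM

Of the compounds shown here, three sharing one core have been tested in a functional assay on MCF7 cells (Homo sapiens) for antiproliferative activity, read by sulforhodamine B assay, with a stated time of 3 days; a lower number here means a stronger inhibitor, a higher number a weaker inhibitor. Compound 1 gives 32300 nM, compound 3 gives 31000 nM, and compound 2 gives 44700 nM. Compound 2 holds the highest of the three numbers, but its distance to compound 1 and to compound 3 lies within the usual scatter of repeated measurements, so the three cannot be told apart on these data. Within the data shown here, no single-change step between measured compounds is available.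

The next compound is compound 4, `CSc1ncnc2[nH]cnc12`, which is compound 2 with one change: methylsulfanyl in place of allyloxy on an aromatic carbon. Nothing in the three measured values points in a clear direction for this change, since all three sit close together despite differing groups at this place. A step from compound 2 to compound 4 of no more than the scatter is therefore expected, with the estimate leaning slightly toward a higher number as a 1.1-fold higher number from compound 2 to compound 4 (0.05 log units; within the scatter). In this assay compound 4 is expected to give about 50000 nM, within a range from 18000 nM to 140000 nM.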

Compound 4, half-maximal inhibitory concentration: 23600 nM
The estimate for compound 4 lay 2.1-fold (0.33 log units) above the measured number; low and high end bracket the measured number.
By their numbers in this assay, from the lowest: compounds 4, 3, 1 and 2 (each within the scatter of the next).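

In this assay, among these compounds, methylsulfanyl in place of allyloxy on this aromatic carbon gives the first direct single-change comparison at this place (a 1.9-fold lower number from compound 2 to compound 4 (0.28 log units; within the scatter)). The change removes the double bond outside the aromatic rings, shortens the group from 4 heavy atoms to 2, and exchanges oxygen for sulfur, yet the two compounds cannot be told apart. No measurement shown here explains this result.

Among the compounds shown here, what remains open is whether any group at this aromatic carbon can move the number beyond the scatter, since this one comparison covers only two small groups. An amine, a carboxylic acid or a longer chain on the sulfur would each test that question in a different way, and the compounds shown do not answer it.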